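Series notes: compound 4 as a stereoisomer of compound 3

The compounds below may be only part of what the source reports. "The series", "measured", "known", "first", "only" and "open" are said of these compounds alone.

The series shares one core with a carboxylic acid and a tert-butyl group, varied at the side chain on the saturated ring carbon. Compound 1 `CC(C)(C)C1=C(C(=O)O)N2C(=O)[C@H]([C@H](O)CCc3ccccc3)[C@H]2O1` gives 21 h in an ADME assay, in phosphate buffer, at 28 degrees C, at pH 7.0; a higher number here means that the compound lasts longer, a lower number that the compound disappears faster. Compound 2 `CC(C)(C)C1=C(C(=O)O)N2C(=O)[C@H](CO)[C@@H]2O1` gives 2.4 h in this assay, and compound 3 `CC(C)(C)C1=C(C(=O)O)N2C(=O)[C@H]([C@H](O)CCc3ccncc3)[C@@H]2O1` gives 7.1 h. On these numbers compound 3 stands second of the three, with compound 1 higher and compound 2 lower, both gaps beyond the scatter. For the measured compounds named here, the one step available, a 3.0-fold higher number from compound 2 to compound 3 (0.47 log units; beyond the scatter), concerns adding the 2-(pyridin-4-yl)ethyl group and says nothing about configuration.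

Compound 4 `CC(C)(C)C1=C(C(=O)O)N2C(=O)[C@H]([C@@H](O)CCc3ccncc3)[C@H]2O1` differs from compound 3 only in configuration: the two compounds have the same atoms and bonds and differ only in configuration as drawn: 2 of 3 stereo elements differ; a stereocentre at a saturated chain carbon is drawn R in compound 3 and S in compound 4; a stereocentre at a saturated ring carbon is drawn S in compound 3 and R in compound 4. Going by the values given here, no measured pair shows the effect of inverting stereocentres, so no step is inferred from the data; a change within the scatter is the default expectation, while the spread between compound 2 and compound 1 marks how far the series can move. Compound 4 is therefore expected to give about 7 h in this assay, within 2.5 h to 20 h, which means an expected step of a 1.0-fold lower number from compound 3 to compound 4 (0.01 log units; within the scatter).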

Compound 4, half-life: 15.8 h
Estimate against measurement, compound 4: 2.3-fold (0.35 log units) below; the measured number falls inside the stated range.
By their numbers in this assay, from the lowest: compound 2; then compound 3; then compounds 4 and 1 (each within the scatter of the next).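

Configuration at this position is now shown to matter: with the chain carbon drawn S rather than R and the ring carbon drawn R rather than S, this assay records a 2.2-fold higher number from compound 3 to compound 4 (0.35 log units; beyond the scatter). The earlier step, a 3.0-fold higher number from compound 2 to compound 3 (0.47 log units; beyond the scatter), concerned adding the 2-(pyridin-4-yl)ethyl group, so it showed only that the half-life moves with a change of substituent, whereas this step shows that it also moves when the substituent stays the same. The step can be assigned to stereochemistry alone, with no contribution from a change in atoms or bonds, because nothing else separates the pair: the fact that compounds 3 and 4 differ only in the configuration as drawn

The two stereocentres change together in this pair, so the compounds shown leave open whether the chain carbon, the ring carbon or both together account for the step, and a stereoisomer with only one of them inverted would separate these cases. Also open, on these data alone, is whether a similar effect of configuration appears when a longer chain replaces the 2-(pyridin-4-yl)ethyl group, or when an amine replaces the hydroxyl on the saturated chain carbon.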